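The compounds below may be only part of what the source reports. "The series", "measured", "known", "first", "only" and "open" are said of these compounds alone.

Measured compounds:
Compound 1, `N#CC1=C(N)Oc2c(c3nc4ccccc4nc3c3ccccc23)C12C(=O)N(Cc1cnnn1-c1ccccc1Cl)c1ccccc12` — > 50000 nM in an ADME assay on L02 cells (Homo sapiens) for antiproliferative activity, read by MTT assay, with a stated time of 48 h; a lower number here means a stronger inhibitor, a higher number a weaker inhibitor
Compound 2, `COc1ccc(-n2nncc2CN2C(=O)C3(C(C#N)=C(N)Oc4c3c3nc5ccccc5nc3c3ccccc43)c3ccccc32)cc1` — > 50000 nM
Compound 3, `CCOc1ccccc1-n1nncc1CN1C(=O)C2(C(C#N)=C(N)Oc3c2c2nc4ccccc4nc2c2ccccc32)c2ccccc21` — > 50000 nM

In this assay compound 1 gives > 50000 nM, which is a limit of the assay and not a number. Compound 2 gives > 50000 nM, again only a limit. Compound 3 also gives > 50000 nM, a limit once more. Compound 3 therefore stands nowhere in particular among the values shown: all three sit at the limit of > 50000 nM in this assay, at which 3 of the 3 values shown sit. The steps between these compounds cannot be read, as a step that the two limits leave unreadable from compound 1 to compound 2, a step that the two limits leave unreadable from compound 1 to compound 3 and a step that the two limits leave unreadable from compound 2 to compound 3 show, so none of them tells which group on the aromatic nitrogen matters in this assay.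

Compound 4, `CC(=O)Nc1ccc(-n2nncc2CN2C(=O)C3(C(C#N)=C(N)Oc4c3c3nc5ccccc5nc3c3ccccc43)c3ccccc32)cc1`, differs from compound 3 by 4-acetamidophenyl in place of 2-ethoxyphenyl on an aromatic nitrogen. The measured steps bear on this change only in that every variation of the group on the aromatic nitrogen so far has left the value at the limit. No step beyond the scatter is expected, and the estimated step that the limit leaves unreadable from compound 3 to compound 4 reflects that. Compound 4 is expected to give about 80000 nM, within 40000 nM to 200000 nM, most likely again reported only as a limit.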

Compound 4, half-maximal inhibitory concentration: > 50000 nM
Compound 4: no number, only a limit; the forecaster's own chance of this, stated with the estimate: 85%; the middle value is on the limit's open side.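

In this assay compound 4 gives > 50000 nM, which is a limit and not a number. The steps from compound 1, compound 2 and compound 3 to compound 4 therefore cannot be read. The compounds shown leave open whether the group on the aromatic nitrogen matters at all in this assay.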